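This account rests on a few compounds, and the source may have more. Where it says the series, first, only, none or still open, it means among the compounds named here.

Compound 2 `CNC(=O)c1cc(C(=O)N[C@H]2[C@@H]3COC[C@@H]32)c([C@@H](C)c2ccccc2)o1` is the starting point of this step. In an ADME assay on cells (Hepatocyte, Homo sapiens) for metabolic stability, read by LC-MS, with a stated time of 120 min (on this read-out lower numbers stand for slow clearance and higher numbers for fast clearance), compound 2 reports only a limit of the assay, < 0.45 mL/min, so its clearance is not fixed to a single number. Compound 1 `CNC(=O)c1cc(C(=O)N[C@H]2CC[C@H](O)CC2)n([C@@H](C)c2ccccc2)n1`, a related compound, likewise reports only a limit in this assay, < 0.5 mL/min. Within the data shown here, both values shown are limits, the limit of < 0.45 mL/min in this assay, at which 1 of the 2 values shown sits, and (the limit of < 0.5 mL/min in this assay, at which 1 of the 2 values shown sits), and no measured step between compounds is available. Compound 3 `CNC(=O)c1cc(C(=O)N[C@H]2[C@@H]3C[C@@H](O)C[C@@H]32)c([C@@H](C)c2ccccc2)o1` differs from compound 2 in one place: a group of 7 heavy atoms (6 carbon, 1 oxygen; one three-membered non-aromatic ring of carbon only, one five-membered non-aromatic ring of carbon only) in place of a group of 6 heavy atoms (5 carbon, 1 oxygen; one three-membered non-aromatic ring of carbon only, one five-membered non-aromatic ring with 1 hetero atom), on an amide-type nitrogen. With both known compounds sitting at a limit, the expectation for compound 3 is no change beyond the usual scatter, and it is expected to stay close to the limit as well. Compound 3 is estimated at 0.4 mL/min, with a range from 0.2 mL/min to 0.9 mL/min. This estimate corresponds to an expected step that the limit leaves unreadable from compound 2 to compound 3, within the scatter.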

Compound 3, intrinsic clearance in a liver preparation (reported as CLH), per the amount of preparation that the assay uses in the Hepatocyte assay: < 0.45 mL/min
Compound 3 gave a limit, no number; the forecaster's own chance of this, stated with the estimate: 65%; the middle value lies beyond the limit too.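

Compound 2 and compound 3 both report only a limit in the Hepatocyte assay, and the step between them cannot be read. In a physicochemical assay for lipophilicity (on this read-out higher numbers stand for higher lipophilicity and lower numbers for lower lipophilicity), compound 2 gives 4.1, and compound 3 gives 2.8. Going by these compounds, the actual clearance of compound 2 and of compound 3, and any difference between them, stays open.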